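The source may report more compounds than this note shows. Statements on the series, on what has been measured and on what is new or still open speak of the compounds shown alone.

Within the data shown here, compound 3, with structure `COc1ccc(-c2cc(=O)c3c(OC)cc(OC)cc3n2S(=O)(=O)c2ccc([N+](=O)[O-])cc2)cc1`, is the only member of this small set to give a number in a functional assay on SUP-B15 cells (Homo sapiens) for antiproliferative activity, with a stated time of 72 h; a higher number here means that more compound is needed for the effect, a lower number that less compound is needed: compound 3 gives 17100 nM. Compound 1, with structure `COc1ccc(-c2[nH]c3cc(OC)cc(OC)c3c(=O)c2I)cc1`, reaches only the limit of the assay, > 86200 nM. Compound 2, with structure `COc1ccc(-c2cc(=O)c3c(OC)cc(OC)cc3n2S(=O)(=O)c2ccc(C=O)cc2)cc1`, likewise reaches only a limit, > 34400 nM. Among the measured compounds shown here, the single measured step, from compound 2 to compound 3, is an at least 2.0-fold lower number from compound 2 to compound 3 (0.30 log units; that floor lies within the scatter), and it rests on (the limit of > 34400 nM in this assay, at which 1 of the 3 values shown sits), so its true size is open; the other limit, (the limit of > 86200 nM in this assay, at which 1 of the 3 values shown sits), belongs to a compound of a different core and says nothing about the sulfonyl aryl group.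

Compound 4, with structure `COc1ccc(-c2cc(=O)c3c(OC)cc(OC)cc3n2S(=O)(=O)c2ccc(C)c([N+](=O)[O-])c2)cc1`, differs from compound 3 in one place: 4-methyl-3-nitrophenyl in place of 4-nitrophenyl on a sulfonyl sulfur. For the measured compounds named here, the only measured step that touches the group on the sulfonyl sulfur is the one from compound 2 to compound 3, whose floor lies within the scatter and which involves a different pair of groups. Nothing here therefore points to a change beyond the scatter in this assay, in either direction, and compound 4 is expected to sit close to compound 3, so that the estimated step from compound 3 to compound 4 is a 1.0-fold lower number from compound 3 to compound 4 (0.00 log units; within the scatter). The expected value for compound 4 is 17000 nM, with a range from 6000 nM to 50000 nM.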

Compound 4, half-maximal effective concentration: > 51700 nM
Compound 4: a limit, no number (the forecaster's own chance of this, stated with the estimate: 30%); middle value at least 3.0-fold (0.48 log units) from the limit.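

In this assay, the group on the sulfonyl sulfur now gives a step beyond the scatter, which the earlier step between the formyl and nitro compounds could not establish: an at least 3.0-fold higher number from compound 3 to compound 4 (0.48 log units; beyond the scatter). The position is therefore not indifferent to this change, since 4-methyl-3-nitrophenyl in place of 4-nitrophenyl does not keep the number that compound 3 has. Compound 4 gives only a limit, so the true size of this step stays open: the limit of > 51700 nM in this assay, at which 1 of the 4 values shown sits.

The step between compound 2 and compound 4 cannot be read, as both values are limits. Also open, as far as these compounds go, is whether the methyl or the changed nitro placement carries the step, and whether an amine or a carboxylic acid on this phenyl ring would give a lower number than compound 3 does.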